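This account rests on a few compounds, and the source may have more. Where it says the series, first, only, none or still open, it means among the compounds named here.

Within the data shown here, in an ADME assay on Vero cells (Chlorocebus sabaeus) for cytotoxicity, read by MTT assay, with a stated time of 72 h (a lower number here means that less compound is tolerated, a higher number that more compound is tolerated), compound 1 (`CC/C(=C\c1ccc(Cl)cc1)C(=O)/C=C/c1ccc([N+](=O)[O-])cc1`) gives 36000 nM as the lower of the two numbers so far, and compound 2 (`COc1ccc(/C=C(\C)C(=O)/C=C/c2cccc(Cl)c2Cl)cc1`) gives 119000 nM as the higher, a gap beyond the usual scatter. Compound 3 (`CC/C(=C\c1ccc(Cl)cc1)C(=O)/C=C/c1ccc(Cl)cc1`) has not yet been measured. It keeps the core of compound 1 but carries chloro in place of nitro on an aromatic carbon, para to a large group (chloro in place of nitro on an aromatic carbon). Among the measured compounds shown here, no measured pair shows this exchange directly. Compound 2 also carries chloro on an aromatic ring and gives 119000 nM in this assay but differs from compound 1 elsewhere too, so it is only a weak hint. A small rise is therefore expected, one that may stay within the scatter. The estimated step is a 1.7-fold higher number from compound 1 to compound 3 (0.22 log units; within the scatter) and points upward. Compound 3 is expected to give 60000 nM with an estimated range of 20000 nM to 170000 nM in this test.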

Compound 3, half-maximal cytotoxic concentration: 28300 nM
Estimate against measurement, compound 3: 2.1-fold (0.33 log units) above, within the range that was stated.
By their numbers in this assay, from the lowest: compounds 3 and 1 (each within the scatter of the next); then compound 2.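

In this assay, chloro in place of nitro on this aromatic carbon, para to a large group, gives a 1.3-fold lower number from compound 1 to compound 3 (0.10 log units; within the scatter). This direct pair shows that, on the core of compound 1, the nitro group can give way to a single chlorine without a difference that stands out from the usual scatter of this test. No measurement shown here offers an explanation for this result.

From the compounds shown here alone, whether this position would accept other kinds of group equally well stays open, for example an amine, a carboxylic acid or a longer chain such as butyl. Going by these compounds, it is also open whether chloro and nitro would give matching numbers on a core that differs elsewhere, since this single pair speaks only for the core of compound 1.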